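Moving the Trifluoromethyl Group: Compound 3 to Compound 4

The source may hold more compounds than are shown below. What is called first, only, known or untested is meant among the compounds shown, and "the series" means these compounds.

Three compounds share one core and differ only in the aryl group on an amine nitrogen in a ring. Compound 1 `Nc1scc(CN2CCN(c3ccc(F)cc3Cl)CC2)c1C(=O)c1ccc(Cl)cc1` gives -6.2% in a functional assay on CHO cells with adenosine receptor A1 (Homo sapiens) as the target, read by cAMP accumulation and immunoassay, with a stated time of 6 min, tested at 0.1 uM (on this read-out higher numbers stand for a weaker effect at the one concentration tested and lower numbers for a stronger effect), and compound 2 `Nc1scc(CN2CCN(c3ccc(Cl)cc3F)CC2)c1C(=O)c1ccc(Cl)cc1` gives -9.4%; the step of a number 3.2 percentage points lower from compound 1 to compound 2 (within the scatter) lies within the scatter. Compound 3 `Nc1scc(CN2CCN(c3cccc(C(F)(F)F)c3)CC2)c1C(=O)c1ccc(Cl)cc1` gives -30%, the lowest number of the three; the steps of a number 23.8 percentage points lower from compound 1 to compound 3 (beyond the scatter) and a number 20.6 percentage points lower from compound 2 to compound 3 (beyond the scatter) are both beyond the scatter, so compound 3 stands as the strongest of the three on this read-out. Compound 4 `Nc1scc(CN2CCN(c3ccccc3C(F)(F)F)CC2)c1C(=O)c1ccc(Cl)cc1` has not been measured. The change is 2-(trifluoromethyl)phenyl in place of 3-(trifluoromethyl)phenyl on an amine nitrogen in a ring. Going by the values given here, no measured step moves a trifluoromethyl group from one place on the aryl ring to another; the nearest comparison is the exchange of 2-chloro-4-fluorophenyl for 4-chloro-2-fluorophenyl, which stayed within the scatter, while the two larger steps came from replacing one aryl group by a different one. Compound 4 is therefore expected to show a step of a number 8 percentage points higher from compound 3 to compound 4 (within the scatter) in this assay, not beyond the scatter. Compound 4 is estimated at -22%, with a range from -42% to -2%.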

Compound 4, a percentage reported as activity, at one concentration (the size of the read-out at that concentration, not a potency): -7.5%
The estimate for compound 4 lay 14.5 percentage points below the measured number; the measured number falls inside the stated range.
By their numbers in this assay, from the lowest: compound 3; then compounds 2, 4 and 1 (each within the scatter of the next).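

In this assay, going by these compounds alone, moving the trifluoromethyl group while keeping the same atoms gives a number 22.5 percentage points higher from compound 3 to compound 4 (beyond the scatter), whereas the earlier steps beyond the scatter came from exchanging one aryl group for a different one. The new compound also sits within the scatter of the two chloro-fluoro compounds, with a number 1.9 percentage points higher from compound 2 to compound 4 (within the scatter) and a number 1.3 percentage points lower from compound 1 to compound 4 (within the scatter), so among these four compounds only compound 3, with its 3-(trifluoromethyl)phenyl group, stands apart on this read-out. Nothing given here bears on why this shift of one group has this result.

As far as these compounds go, it remains open whether a nitrile or a methoxy group moved in the same way on the phenyl ring would give a similar step. From the compounds shown here alone, with each compound read at a single concentration, whether compound 3 would also show a stronger effect than compound 4 at other concentrations remains open.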